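Lengthening the acid chain: from compound 2 to compound 4

The source may hold more compounds than are shown below. What is called first, only, known or untested is meant among the compounds shown, and "the series" means these compounds.

Compound 2 `CCCc1c(COc2ccc(C(=O)CCC(=O)O)cc2)ccc(C(C)=O)c1O` gives 18.2 mg/kg in an in vivo functional assay on the whole organism (Rattus norvegicus) with cysteinyl leukotriene receptor (Homo sapiens) as the target (on this read-out lower numbers stand for an effect already at smaller amounts and higher numbers for an effect only at larger amounts of compound), the second highest of three numbers. Compound 1 `CCCc1c(COc2ccc(C(=O)Cc3nnn[nH]3)cc2)ccc(C(C)=O)c1O` gives 24.1 mg/kg and compound 3 `CCCc1c(COc2ccc(C(=O)CCc3nnn[nH]3)cc2)ccc(C(C)=O)c1O` gives 10.1 mg/kg; the steps of a 1.3-fold lower number from compound 1 to compound 2 (0.12 log units; within the scatter) and a 1.8-fold lower number from compound 2 to compound 3 (0.26 log units; within the scatter) both stay within the scatter. Compound 4 `CCCc1c(COc2ccc(C(=O)CCCC(=O)O)cc2)ccc(C(C)=O)c1O` has not yet been measured; it differs from compound 2 by carboxymethyl in place of carboxy on a saturated chain carbon, two bonds along the chain from a carbonyl carbon. Within the data shown here, the closest precedent is the comparable chain lengthening on the tetrazole side, a 2.4-fold lower number from compound 1 to compound 3 (0.38 log units; beyond the scatter), a modest gain. The same lengthening on the acid chain is expected to give a modest lower number or none beyond the scatter, so the step of a 1.4-fold lower number from compound 2 to compound 4 (0.15 log units; within the scatter) is the estimate. Compound 4 is therefore expected to reach about 13 mg/kg, within 6 mg/kg to 30 mg/kg.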

Compound 4, dose for half-maximal effect: 9.5 mg/kg
The estimate for compound 4 lay 1.4-fold (0.14 log units) above the measured number; the measured number falls inside the stated range.
By their numbers in this assay, from the lowest: compounds 4, 3, 2 and 1 (each within the scatter of the next, the first and the last beyond it).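

Lengthening the acid chain by one carbon gives a 1.9-fold lower number from compound 2 to compound 4 (0.28 log units; within the scatter), so this position accepts the longer chain with no clear change. The longer acid chain stands apart only from the shorter 1H-tetrazol-5-yl compound, with a 2.5-fold lower number from compound 1 to compound 4 (0.40 log units; beyond the scatter), whereas a 1.1-fold lower number from compound 3 to compound 4 (0.03 log units; within the scatter) shows no clear separation from the longer one. Carboxymethyl in place of 1H-tetrazol-5-yl thus reads alike on two cores: the same change on two cores in this assay, a 1.3-fold lower number (0.12 log units; within the scatter) from compound 1 to compound 2 and a 1.1-fold lower number (0.03 log units; within the scatter) from compound 3 to compound 4, 1.2-fold (0.10 log units) apart, within the scatter of two such steps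

As far as these compounds go, whether a still longer acid chain would hold this level remains open. So does the effect of an amide in place of the carboxylic acid at the chain end.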